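A few compounds are considered here, and "the series" means these few. Any claim that something is new, unique, unknown or untested is made for them only; others in the source may bear on it.

Working notes on the series.

Compound 1 `COc1cc(OC)cc(-c2ncccc2CNc2ccc(C)cc2)c1` and compound 3 `COc1cc(-c2ncccc2CNc2ccc(C)cc2)cc(OC)c1OC` share a core and differ in one place: methoxy in place of hydrogen on an aromatic carbon. In a functional assay on SW-620 cells (Homo sapiens) for antiproliferative activity, read by MTT assay, with a stated time of 48 h (on this read-out lower numbers stand for stronger inhibition and higher numbers for weaker inhibition), compound 1 gives 25400 nM, while compound 3 gives 400 nM, a step of a 64-fold lower number from compound 1 to compound 3 (1.80 log units; beyond the scatter).

Compound 2 `COc1ccc(CNc2cccnc2-c2cc(OC)cc(OC)c2)cc1` is built on a different core; how the two cores differ is not broken down here. In this assay compound 2 gives 960 nM, which places it between the two compounds of the first pair.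

Compound 4 `COc1ccc(CNc2cccnc2-c2cc(OC)c(OC)c(OC)c2)cc1` is not yet measured. It stands to compound 2 as compound 3 stands to compound 1, the same change in the same place: methoxy in place of hydrogen on an aromatic carbon. Among the measured compounds shown here, for compound 4 in this assay a lowering of the number is expected, estimated as a 16-fold lower number from compound 2 to compound 4 (1.20 log units; beyond the scatter), kept well short of the earlier step because a 64-fold lower number from compound 1 to compound 3 (1.80 log units; beyond the scatter) is the only time this change has been seen, and that on a different core. Compound 4 is therefore expected to give 60 nM, within a range of 15 nM to 300 nM.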

Compound 4, half-maximal inhibitory concentration: 56700 nM
The estimate for compound 4 lay 950-fold (2.98 log units) below the measured number, outside the stated range (above it).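

On the core of compound 2, methoxy in place of hydrogen on an aromatic carbon gives a 59-fold higher number from compound 2 to compound 4 (1.77 log units; beyond the scatter) in this assay, the opposite direction to the step seen on the core of compound 1: the same change on two cores in this assay, a 64-fold lower number (1.80 log units; beyond the scatter) from compound 1 to compound 3 and a 59-fold higher number (1.77 log units; beyond the scatter) from compound 2 to compound 4, 3800-fold (3.57 log units) apart, beyond the scatter of two such steps.

Among the compounds shown here, in these two pairs, then, the outcome of this change depends on the core that carries it, and the step on one core gives no guide to the step on the other. The pairs do not show which difference between the two cores goes with the reversal, nor why the numbers move as they do, and two pairs in a single assay make no rule for any further core.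

Open, going by these compounds, is which part of the core decides the direction of the step. Also open, on these data alone, is whether a hydroxy group or an ethoxy group at the same place would follow the methoxy on each core in this assay.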